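The compounds below may be only part of what the source reports. "The series", "measured", "known", "first", "only" and "open" are said of these compounds alone.

Measured so far in a functional assay, read by Griess assay, with a stated time of 150 min, tested at 100 ug/mL; on this read-out lower numbers stand for a weaker effect and higher numbers for a stronger effect at the one concentration tested:
compound 1 `COc1ccc(C2=NN(c3ccccc3)C(c3ccc(C)cc3)C2S(=O)(=O)CC2=NCCO2)cc1`, 70.5%;
compound 2 `COc1ccc(C2=NN(c3ccccc3)C(c3ccc(C)cc3)C2S(=O)(=O)CC2=NCCS2)cc1`, 50.7%;
compound 3 `COc1ccc(C2=NOC(c3ccc(C)cc3)C2S(=O)(=O)CC2=NCCO2)cc1`, 71.3%.

Compound 1 and compound 2 share one core and differ in a single place: a group of 5 heavy atoms (3 carbon, 1 nitrogen, 1 sulfur; one five-membered non-aromatic ring with 2 hetero atoms) in place of a group of 5 heavy atoms (3 carbon, 1 nitrogen, 1 oxygen; one five-membered non-aromatic ring with 2 hetero atoms), on a saturated chain carbon bound to a sulfonyl sulfur. That change produced a number 19.8 percentage points lower from compound 1 to compound 2 (beyond the scatter) in this assay. Compound 3 is built on a different core; how the two cores differ is not broken down here. In this assay, among the measured compounds shown here, compound 3 gives 71.3%, a number that lies within the scatter of the one for compound 1, so the two cannot be ranked against each other. Compound 4 `COc1ccc(C2=NOC(c3ccc(C)cc3)C2S(=O)(=O)CC2=NCCS2)cc1` has not yet been measured. It differs from compound 3 by a group of 5 heavy atoms (3 carbon, 1 nitrogen, 1 sulfur; one five-membered non-aromatic ring with 2 hetero atoms) in place of a group of 5 heavy atoms (3 carbon, 1 nitrogen, 1 oxygen; one five-membered non-aromatic ring with 2 hetero atoms), on a saturated chain carbon bound to a sulfonyl sulfur, the same change that separates compound 2 from compound 1, at the same place. Because that change gave a number 19.8 percentage points lower from compound 1 to compound 2 (beyond the scatter), the expected step here is a number 19.3 percentage points lower from compound 3 to compound 4 (beyond the scatter), resting on a single earlier pair only. Compound 4 is accordingly estimated at 52%, with a likely range from 38% to 66%.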

Compound 4, a percentage reported as activity, at one concentration (the size of the read-out at that concentration, not a potency): 59.6%
Estimate against measurement, compound 4: 7.6 percentage points below; the range from low to high includes it.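

On the second core, putting the sulfur-containing group in place of the oxygen-containing group, on a saturated chain carbon bound to a sulfonyl sulfur, gave a number 11.7 percentage points lower from compound 3 to compound 4 (beyond the scatter) in this assay. The change therefore lowers the number on both cores shown, and the sizes of the two steps cannot be told apart: the same change on two cores in this assay, a number 19.8 percentage points lower (beyond the scatter) from compound 1 to compound 2 and a number 11.7 percentage points lower (beyond the scatter) from compound 3 to compound 4, 8.1 percentage points apart, within the scatter of two such steps. This supports carrying the change between these two cores, but it rests on one pair per core at one concentration, so it shows neither that the step would hold on a third core nor why the sulfur-containing group lowers the number.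

The compounds shown leave open what a carboxylic acid, an amine or a longer chain would give on that saturated chain carbon in place of either five-membered ring. They also leave open whether the step would keep its size with something other than the methoxy and methyl groups, which are the same in all four compounds.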